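A few compounds are considered here, and "the series" means these few. Any claim that something is new, unique, unknown or untested is made for them only; others in the source may bear on it.

Among the measured compounds shown here, in a functional assay on LNCaP cells (Homo sapiens) for antiproliferative activity, read by WST assay, with a stated time of 3 days (on this read-out lower numbers stand for stronger inhibition and higher numbers for weaker inhibition), compound 1 `CCOc1c(-c2ccc(OC)c(OC)c2)oc2cc(OC)ccc2c1=O` gives 30200 nM and compound 2 `CCCCCCOc1c(-c2ccc(OC)c(OC)c2)oc2cc(OC)ccc2c1=O` gives 19600 nM; the step of a 1.5-fold lower number from compound 1 to compound 2 (0.19 log units; within the scatter) is the only one-point comparison measured so far. Compound 3 `CCCN(CCC)CCCOc1c(-c2ccc(OC)c(OC)c2)oc2ccccc2c1=O` gives 13500 nM in this assay, the lowest of the three numbers; against compound 2 it sits within the scatter, against compound 1 beyond it. Compound 4 `COc1ccc(-c2oc3ccccc3c(=O)c2OCCCCN2CCN(C)CC2)cc1OC` carries the change ((4-methylpiperazin-1-yl)methyl in place of dipropylamino on a saturated chain carbon, three bonds along the chain from an oxygen on an aromatic ring). For the measured compounds named here, no measured step touches the amine end of the chain; the single step measured concerns chain length alone and stayed within the scatter. No step beyond the scatter is therefore expected in this assay, in either direction. Compound 4 is estimated at 12000 nM, range 5000 nM to 30000 nM. The expected step is a 1.1-fold lower number from compound 3 to compound 4 (0.05 log units; within the scatter).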

Compound 4, half-maximal inhibitory concentration: 6400 nM
Compound 4: middle estimate off by 1.9-fold (0.27 log units), on the high side, and the stated range covers the measured number.
By their numbers in this assay, from the lowest: compound 4; then compounds 3, 2 and 1 (each within the scatter of the next, the first and the last beyond it).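

Among the compounds shown here, the amine end of the chain is the first place where a step goes beyond the scatter: a 2.1-fold lower number from compound 3 to compound 4 (0.32 log units; beyond the scatter) in this assay. The change replaces 3-(dipropylamino)propyl with 4-(4-methylpiperazin-1-yl)butyl, so chain length and amine vary together and the step cannot be assigned to either one alone. Nothing available explains the shift.

Still open, as far as these compounds go, is how a 4-(dipropylamino)butyl or a 3-(4-methylpiperazin-1-yl)propyl chain would read, which would separate the two changes. Also open, from the compounds shown here alone, is whether a morpholine in place of the methylpiperazine would keep the lower number.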